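The source may report more compounds than this note shows. Statements on the series, on what has been measured and on what is new or still open speak of the compounds shown alone.

Going by the values given here, in a functional assay on PC-3 cells (Homo sapiens) for cytotoxicity, read by MTT assay, with a stated time of 72 h (on this read-out higher numbers stand for weaker inhibition and lower numbers for stronger inhibition), compound 2 `Cn1ccc2c(Oc3ccc(NC(=O)c4nn(-c5ccc(Br)cc5)ccc4=O)cc3)ccnc21` stands at the top of the two numbers known so far, giving 23000 nM. Among the compounds with values here, its only measured neighbour is compound 1 `O=C(Nc1ccc(Oc2ccnc3[nH]ccc23)cc1)c1nn(-c2ccc(Br)cc2)ccc1=O`, which in this assay gives 8040 nM; the one measured step, a 2.9-fold higher number from compound 1 to compound 2 (0.46 log units; beyond the scatter), concerns methyl in place of hydrogen on an aromatic nitrogen and is modest but beyond the scatter. Compound 3 `Cn1ccc2c(Oc3ccc(NC(=O)c4nn(-c5ccc(Cl)c(C(F)(F)F)c5)ccc4=O)cc3)ccnc21` is not yet measured. It differs from compound 2 by 4-chloro-3-(trifluoromethyl)phenyl in place of 4-bromophenyl on an aromatic nitrogen. Within the data shown here, no measured step bears on this change: the single step known alters a different place on the shared core, so it offers no guide to the direction. Compound 3 is therefore expected to sit close to compound 2 in this assay, with a step of no change at the digits printed from compound 2 to compound 3 (within the scatter) that is not expected to pass the scatter. The estimate for compound 3 is 23000 nM, within a range from 7000 nM to 70000 nM.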

Compound 3, half-maximal inhibitory concentration: 10300 nM
Compound 3: the middle estimate sits 2.2-fold (0.35 log units) above what was measured; the range from low to high includes it.
By their numbers in this assay, from the lowest: compounds 1 and 3 (each within the scatter of the next); then compound 2.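

In this assay, going by these compounds alone, 4-chloro-3-(trifluoromethyl)phenyl in place of 4-bromophenyl on an aromatic nitrogen gives a 2.2-fold lower number from compound 2 to compound 3 (0.35 log units; beyond the scatter) as a modest step, so this position, which did not vary between the earlier compounds, does respond to the group it carries. The entering group is the larger of the two by heavy atoms, yet the number falls rather than rises. No measurement at hand accounts for this step.

The change combines chlorine for bromine with an added trifluoromethyl, and the compounds shown do not separate the two. Also open, as far as these compounds go, is how an amine or a carboxylic acid on this phenyl ring would read, and whether the step would hold with the hydrogen of compound 1 on the aromatic nitrogen of the shared core.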